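A few compounds are considered here, and "the series" means these few. Any claim that something is new, unique, unknown or untested is made for them only; others in the source may bear on it.

Measured so far: compound 1 `O=C(CCc1ccc(-c2ccccc2)cc1)c1ncc(-c2ccncc2)o1`, 2.3 nM; compound 2 `N#Cc1cccc(-c2cnc(C(=O)CCc3ccc(-c4ccccc4)cc3)o2)n1`, 2.9 nM.

Going by the values given here, in an assay for inhibition of Fatty-acid amide hydrolase 1 (Rattus norvegicus) (a higher number here means a weaker inhibitor, a lower number a stronger inhibitor), compound 2 stands highest of the two numbers, but its only neighbour, compound 1, lies within the scatter: a 1.3-fold higher number from compound 1 to compound 2 (0.10 log units; within the scatter). The step from compound 2 to compound 3 `N#Cc1cccc(-c2cnc(C(=O)CCc3ccc(COc4ccccc4)cc3)o2)n1` changes the far end of the molecule: phenoxymethyl in place of phenyl on an aromatic carbon. No measured step touches that end, so nothing shown bears directly on it; the one known step was small. Compound 3 is therefore expected at 5 nM, ranging from 1.5 nM to 20 nM. That estimate means a 1.7-fold higher number from compound 2 to compound 3 (0.24 log units; within the scatter).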

Compound 3, inhibition constant: 0.56 nM
For compound 3 the middle estimate is 8.9-fold (0.95 log units) above the measured one; the measured number lies below the stated range.
By their numbers in this assay, from the lowest: compound 3; then compounds 1 and 2 (each within the scatter of the next).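

In this assay, the far end of the molecule turns out to matter: phenoxymethyl in place of phenyl, para to a large group, gives a 5.2-fold lower number from compound 2 to compound 3 (0.71 log units; beyond the scatter) while the earlier change at the other end stayed within the scatter. Going by these compounds alone, with only this one pair, the gain cannot be divided between the added oxygen and the added carbon. Nothing measured here explains it.

On these data alone, whether phenoxyethyl, with its longer chain, or an amine in place of the oxygen would do the same stays open. So does whether the gain would carry over with pyridin-4-yl, as in compound 1.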